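This account rests on a few compounds, and the source may have more. Where it says the series, first, only, none or still open, it means among the compounds named here.

For the measured compounds named here, in a functional assay on A549 cells (Homo sapiens) for antiproliferative activity, read by MTT assay, with a stated time of 72 h (on this read-out lower numbers stand for stronger inhibition and higher numbers for weaker inhibition), compound 1 (`COc1ccc(OCCCON2C(N)=NC(N)=NC23CCOCC3)cc1`) gives 660 nM and stands highest of the two numbers so far, beyond the scatter from compound 2 (`NC1=NC2(CCSCC2)N(OCCCOc2cccc(Cl)c2)C(N)=N1`), whose 60 nM is the lower number. Compound 3 (`NC1=NC2(CCOCC2)N(OCCCOc2cccc(Cl)c2Cl)C(N)=N1`) follows from compound 1 with 2,3-dichlorophenyl in place of 4-methoxyphenyl on an oxygen on a saturated carbon. Going by the values given here, no measured step isolates this change, so the expectation rests only on compound 2 at 60 nM as the lower number. In this assay a moderate fall beyond the scatter is expected, an estimated step of a 4.4-fold lower number from compound 1 to compound 3 (0.64 log units; beyond the scatter) on this thin evidence. Compound 3 is estimated at 150 nM within 30 nM to 700 nM as its expected range.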

Compound 3, half-maximal inhibitory concentration: 100 nM
Compound 3: middle estimate off by 1.5-fold (0.18 log units), on the high side; the measured number falls inside the stated range.
By their numbers in this assay, from the lowest: compounds 2 and 3 (each within the scatter of the next); then compound 1.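

In this assay the swap of 4-methoxyphenyl for 2,3-dichlorophenyl on an oxygen on a saturated carbon gives a 6.6-fold lower number from compound 1 to compound 3 (0.82 log units; beyond the scatter) with the rest of compound 1 unchanged. For the compounds shown here, this is the first single-place reading at this position, and it shows that the number responds to the aromatic group here, which the earlier pair, differing in more than one place, could not show. No measurement at hand accounts for the step. Still open, going by these compounds, is whether a single chlorine would give a similar step, and how an amine or carboxylic acid on the phenyl ring, or a longer chain, would read.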